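Hydroxy in Place of Trifluoromethyl: An Expected Loss of Potency

The source may hold more compounds than are shown below. What is called first, only, known or untested is meant among the compounds shown, and "the series" means these compounds.

Compound 1 `O=C(Nc1ccc(C(F)(F)F)cc1)C1CCc2ccccc2N1` and compound 2 `CCCCCCCCC(=O)N1c2ccccc2CCC1C(=O)Nc1ccccc1C(F)(F)F` share a core; the difference between the two cores is not broken down here. In a functional assay on NUGC-3 cells (Homo sapiens) for cytotoxicity, read by sulforhodamine B assay, with a stated time of 72 h (a lower number here means a stronger inhibitor of growth, a higher number a weaker inhibitor of growth), compound 1 gives 18600 nM, and compound 2 gives 6180 nM. Compound 3 `O=C(Nc1ccc(O)cc1)C1CCc2ccccc2N1` differs from compound 1 by hydroxy in place of trifluoromethyl on an aromatic carbon. In this assay compound 3 gives > 100000 nM, which is a limit of the assay and not a number (the limit of > 100000 nM in this assay, at which 1 of the 3 values shown sits). The step of an at least 5.3-fold higher number from compound 1 to compound 3 (0.73 log units; beyond the scatter) thus weakens growth inhibition. Compound 4 `CCCCCCCCC(=O)N1c2ccccc2CCC1C(=O)Nc1ccccc1O` carries the same kind of change on compound 2, namely (hydroxy in place of trifluoromethyl on an aromatic carbon), though here the hydroxy sits ortho to a large group whereas in compound 3 it sits para to a large group. Compound 4 is expected to weaken by a 6.5-fold higher number from compound 2 to compound 4 (0.81 log units; beyond the scatter) in this assay, resting on an at least 5.3-fold higher number from compound 1 to compound 3 (0.73 log units; beyond the scatter). Compound 4 is therefore estimated at 40000 nM, likely between 12000 nM and 120000 nM.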

Compound 4, concentration for 50% growth inhibition: 31100 nM
For compound 4 the middle estimate is 1.3-fold (0.11 log units) above the measured one, within the range that was stated.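

With a 5.0-fold higher number from compound 2 to compound 4 (0.70 log units; beyond the scatter) in this assay hydroxy in place of trifluoromethyl weakens growth inhibition on the core of compound 2 as well as on the core of compound 1. Set side by side, the two steps point the same way: the same change on two cores in this assay, an at least 5.3-fold higher number (0.73 log units; beyond the scatter) from compound 1 to compound 3 and a 5.0-fold higher number (0.70 log units; beyond the scatter) from compound 2 to compound 4; the limit leaves it open whether they differ. Compound 3 gives > 100000 nM which is a limit of the assay and not a number, and two cores in a single assay do not show that the change would act the same way on other cores in this series.

Still open, on these data alone, is how an amine, a carboxylic acid or a methoxy group at this place would compare with hydroxy and trifluoromethyl. Also open, as far as these compounds go, is whether the size of the step depends on where on the aromatic ring the group sits.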